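The compounds below may be only part of what the source reports. "The series", "measured", "known", "first", "only" and "open" are said of these compounds alone.

In a functional assay on CHO cells for agonist activity at Alpha-1A adrenergic receptor (Homo sapiens), read by FLIPR and calcium flux (a higher number here means a larger maximal response, a lower number a smaller maximal response), compound 2 `Cn1cc(-c2cccc3c2CCC3c2ncc[nH]2)cn1` gives 12%, the smallest of the three responses recorded. Compound 1 `Cc1ccc2c(c1NS(C)(=O)=O)CCC2c1ncc[nH]1`, which shares its core, reaches 83% in this assay, a far larger response that lies beyond the scatter. Compound 3 `CCS(=O)(=O)Nc1cccc(Cc2c[nH]cn2)c1`, built on a different core, gives 96% in this assay, again well beyond the scatter above compound 2. Compound 4 `COc1cccc2c1CCC2c1ncc[nH]1` is not yet measured; it differs from compound 2 by methoxy in place of 1-methyl-1H-pyrazol-4-yl on an aromatic carbon. Because compound 1 on the same core gives 83%, compound 4 is expected to move upward, by an estimated a number 53 percentage points higher from compound 2 to compound 4 (beyond the scatter), a step beyond the scatter. In this assay compound 4 is therefore expected to reach 65%, with a range from 30% to 95%.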

Compound 4, largest response reached (Emax), in percent of the reference or control that the assay uses: 65%
For compound 4 middle estimate and measured number coincide at the digits printed, and the stated range covers the measured number.
By their numbers in this assay, from the lowest: compound 2; then compound 4; then compound 1; then compound 3.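

Among the compounds shown here, at the aromatic carbon ortho to a fused ring, methoxy in place of 1-methyl-1H-pyrazol-4-yl gives in this assay a number 53 percentage points higher from compound 2 to compound 4 (beyond the scatter) and provides the first comparison here of two compounds that differ in one place. The low response of compound 2 therefore does not belong to the shared core alone, and this position strongly affects the maximal response. Nothing available explains the size of this step. Still open, on these data alone, is how an amine, a hydroxyl group or a longer chain such as ethoxy would behave at this carbon.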